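The source may hold more compounds than are shown below. What is called first, only, known or untested is meant among the compounds shown, and "the series" means these compounds.

Measured so far in a toxicity assay on MDCK cells (Canis lupus familiaris) for cytotoxicity, read by crystal violet staining, with a stated time of 48 h; on this read-out higher numbers stand for lower toxicity in this test and lower numbers for higher toxicity in this test:

- Compound 1 `Cc1ccc2[nH]c(=O)c(CN(Cc3ccc(F)cc3)Cc3ccc(C(C)(C)C)cc3)cc2c1`: > 27000 nM, a limit
- Compound 2 `Cc1ccc2[nH]c(=O)c(CN(Cc3ccc(OC(C)C)cc3)Cc3ccc(C(C)(C)C)cc3)cc2c1`: > 5000 nM, a limit

Compound 2 has only a limit in this assay, > 5000 nM. Compound 1 likewise has a limit and no plain number, so the two cannot be placed in order.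

Compound 3 `CCCOc1ccc(CN(Cc2ccc(C(C)(C)C)cc2)Cc2cc3cc(C)ccc3[nH]c2=O)cc1` keeps all of compound 2 except one group, with propyl in place of isopropyl on an oxygen on an aromatic ring. Isopropoxy thus becomes propoxy, and the two compounds have the same atoms, joined differently.

For the measured compounds named here, only one measured step can be consulted, a step that the two limits leave unreadable from compound 1 to compound 2. That step put isopropoxy in place of fluoro, which is a different change, and it offers no size to carry over. No step beyond the usual scatter is therefore expected in this assay, and no direction can be favoured. The estimated step is a step that the limit leaves unreadable from compound 2 to compound 3. For compound 3 the expected value is 8000 nM, with an estimated range from 3000 nM to 25000 nM. The assay may well report only a limit again.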

Compound 3, half-maximal cytotoxic concentration: > 5000 nM
Compound 3: no number, only a limit (the forecaster's own chance of this, stated with the estimate: 70%); the middle value is on the limit's open side.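

In this assay, compound 3 gives > 5000 nM, which is a limit and not a plain number. No step among compound 1, compound 2 and compound 3 can be read, because each of their values is only a limit: the limit of > 5000 nM in this assay, at which 2 of the 3 values shown sit.

On these data alone, whether fluoro, isopropoxy and propoxy differ at all in their toxicity in this test stays open.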